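Swapping methoxy for fluoro on a bis-benzylidene diketopiperazine

A few compounds are considered here, and "the series" means these few. Any claim that something is new, unique, unknown or untested is made for them only; others in the source may bear on it.

Among the compounds with values here, compound 2 `C=CCn1c(=O)/c(=C\c2ccccc2OC)[nH]c(=O)/c1=C\c1ccccc1OC` is, in a functional assay on Huh-7 cells (Homo sapiens) for cytotoxicity, read by CCK-8 assay, with a stated time of 72 h (on this read-out lower numbers stand for stronger inhibition and higher numbers for weaker inhibition), the only compound in this set with a number: compound 2 gives 21200 nM. Its companion compound 1 `COc1ccccc1/C=c1/[nH]c(=O)/c(=C\c2ccccc2OC)n(C)c1=O` is recorded as "not active" (no number reported) in this assay, with no number attached, so compound 2 stands alone as the sole quantified point. The unmeasured compound 3 `C=CCn1c(=O)/c(=C\c2ccccc2F)[nH]c(=O)/c1=C\c1ccccc1OC` differs from compound 2 in one place, (fluoro in place of methoxy on an aromatic carbon). Within the data shown here, no step between two measured compounds is available to show how this assay responds to such a swap, so the expected step from compound 2 to compound 3 is a 1.0-fold higher number from compound 2 to compound 3 (0.02 log units; within the scatter), which is taken as no change beyond the scatter, with the direction left open. Compound 3 is therefore estimated to give 22000 nM in this assay, within a range from 8000 nM to 60000 nM.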

Compound 3, half-maximal inhibitory concentration: 31300 nM
For compound 3 the middle estimate is 1.4-fold (0.15 log units) below the measured one; the measured number falls inside the stated range.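

In this assay, within the data shown here, the first measured swap at this place gives a 1.5-fold higher number from compound 2 to compound 3 (0.17 log units; within the scatter) and so lies within the scatter, which means that 2-methoxyphenyl and 2-fluorophenyl cannot be told apart here on this side of the core. Methoxy, with its two heavy atoms and one hydrogen-bond acceptor, leaves this aromatic carbon and a single fluoro enters, yet the two values stay within the scatter of each other. No measurement is at hand that could explain this result.

The compounds shown leave open whether an amine or a carboxylic acid on this aromatic carbon would move the number beyond the scatter. They also leave open what fluoro would do in place of the methoxy that remains on the other aromatic ring of compound 3.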